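The source may report more compounds than this note shows. Statements on the series, on what has been measured and on what is new or still open speak of the compounds shown alone.

Three compounds of this series have been run in a functional assay on IGROV-1 cells (Homo sapiens) for cytotoxicity, read by sulforhodamine B assay, with a stated time of 48 h, tested at 10 uM; a higher number here means a weaker effect of the compound at the concentration tested, a lower number a stronger effect. Compound 1 `COc1cc(C)cc(-c2c(-c3ccnc(-c4ccc(C(C)=O)cc4)c3)cnn2CC#N)c1` gives 14%, the highest of the three numbers. Compound 2 `COc1cc(C)cc(-c2nn(CC#N)cc2-c2ccc(-c3cccc(C(C)=O)c3)nc2)c1` gives -40%, and compound 3 `COc1cc(C)cc(-c2nn(CC#N)cc2-c2ccnc(-c3ccc(N(C)C)cc3)c2)c1` gives -6%; both sit beyond the scatter under compound 1, compound 2 furthest. Compound 4 `COc1cc(C)cc(-c2c(-c3ccnc(-c4ccc(N(C)C)cc4)c3)cnn2CC#N)c1` is not yet measured in this assay. Set against compound 1 the change is dimethylamino in place of acetyl on an aromatic carbon. Compound 3 also carries a dimethylamino group, and its number lies well under that of compound 1. A downward step is expected here, probably modest but beyond the scatter. The estimated step is a number 16 percentage points lower from compound 1 to compound 4 (beyond the scatter). Compound 4 is accordingly estimated at -2%, with a range from -35% to 28%.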

Compound 4, a percentage reported as activity, at one concentration (the size of the read-out at that concentration, not a potency): -6%
The estimate for compound 4 lay 4 percentage points above the measured number, and the stated range covers the measured number.
By their numbers in this assay, from the lowest: compound 2; then compounds 3 and 4 (each within the scatter of the next); then compound 1.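

Among the compounds shown here, the 4-acetylphenyl to 4-(dimethylamino)phenyl exchange provides the first comparison that differs in one place: this assay shows a number 20 percentage points lower from compound 1 to compound 4 (beyond the scatter) on the shared core. At this position, para to a large group, dimethylamino therefore gives the stronger effect at the concentration tested. Nothing available bears on the cause of this step.

On these data alone, whether this difference is specific to dimethylamino remains open, as does how far it extends beyond acetyl. A primary amine, a morpholine ring or a carboxylic acid at the same position would test this.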